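Removal of a terminal phosphorus group in the bromouracil nucleotide series

The source may report more compounds than this note shows. Statements on the series, on what has been measured and on what is new or still open speak of the compounds shown alone.

Measured so far:
compound 1, `O=c1[nH]c(=O)n([C@@H]2O[C@H](COP(=O)(O)OP(=O)(O)OP(=O)(O)O)[C@@H](O)[C@H]2O)cc1Br` — an in vitro functional assay on 1321-N1 cells for agonist activity at P2Y purinoceptor 2 (Homo sapiens); a higher number here means that more compound is needed for the effect, a lower number that less compound is needed: 347 nM
compound 2, `O=c1[nH]c(=O)n([C@@H]2O[C@H](COP(=O)(O)OP(=O)(O)O)[C@@H](O)[C@H]2O)cc1Br` — this assay: 3670 nM

Compound 2 stands at the highest of the two numbers; its nearest neighbour is compound 1, reached by an 11-fold higher number from compound 1 to compound 2 (1.02 log units; beyond the scatter). Compound 3, `O=c1[nH]c(=O)n([C@@H]2O[C@H](COP(=O)(O)O)[C@@H](O)[C@H]2O)cc1Br`, repeats the same kind of change on compound 2: a hydrogen atom in place of a group of 4 heavy atoms (3 oxygen, 1 phosphorus; no ring), on an oxygen, on an oxygen whose other neighbour is phosphorus. For the measured compounds named here, the only step that bears on it is an 11-fold higher number from compound 1 to compound 2 (1.02 log units; beyond the scatter), a large loss. A step of similar size, to a higher number, is expected for an 11-fold higher number from compound 2 to compound 3 (1.04 log units; beyond the scatter). Compound 3 is therefore estimated at 40000 nM, with a range from 8000 nM to 200000 nM.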

Compound 3, half-maximal effective concentration: > 1000 nM
Compound 3 gave a limit, no number; the forecaster's own chance of this, stated with the estimate: 35%; the middle value lies beyond the limit too.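

Compound 3 gives only a limit in this assay, not a number: the limit of > 1000 nM in this assay, at which 1 of the 3 values shown sits. The step from compound 2 to compound 3 cannot be read, so it does not show whether this change costs activity a second time. Across both removals, the series shows an at least 2.8-fold higher number from compound 1 to compound 3 (0.45 log units; beyond the scatter), which confirms a loss relative to the triphosphate compound 1 but not its full size.

Where compound 3 lies relative to compound 2 remains open. So does the effect of replacing the hydrogen on this oxygen with a methyl group or a thiophosphate.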